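The source may hold more compounds than are shown below. What is called first, only, known or untested is meant among the compounds shown, and "the series" means these compounds.

Measured so far:
Compound 1, `CCc1nc(N)nc(N)c1-c1ccc(NCc2ccnc(Cl)c2)cc1`, gives 110 nM in an in vitro assay on CHOK cells for displacement of a labelled ligand from growth hormone secretagogue receptor type 1 (Homo sapiens); on this read-out lower numbers stand for stronger inhibition and higher numbers for weaker inhibition.
Compound 2, `Nc1nc(N)c(-c2ccc(NCc3ccc([N+](=O)[O-])cc3)cc2)c(COCc2ccccc2)n1`, gives 0.2 nM.
Compound 3, `CC(=O)c1ccc(CNc2ccc(-c3c(N)nc(N)nc3COCc3ccccc3)cc2)cc1`, gives 1.2 nM.

Compound 3 holds the second highest of the three numbers: it sits close to compound 2, separated by a 6.0-fold higher number from compound 2 to compound 3 (0.78 log units; beyond the scatter), where acetyl replaced nitro, while compound 1 lies far higher with no single-step link to it.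

Compound 4, `Nc1nc(N)c(-c2ccc(NCc3ccnc(Cl)c3)cc2)c(COCc2ccccc2)n1`, differs from compound 3 by 2-chloropyridin-4-yl in place of 4-acetylphenyl on a saturated chain carbon bound to a nitrogen on an aromatic ring. Among the compounds with values here, only the step from compound 2 to compound 3 touches this same outer ring, and it was modest; compound 1 carries the entering chloropyridinylmethyl group but a different group on the core, so no measured step isolates this swap. A modest rise is therefore expected, a 3.3-fold higher number from compound 3 to compound 4 (0.52 log units; beyond the scatter), giving an estimated 4 nM for compound 4, between 0.6 nM and 25 nM.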

Compound 4, half-maximal inhibitory concentration: 1.5 nM
Compound 4: middle estimate off by 2.7-fold (0.43 log units), on the high side; measured number inside the range.
By their numbers in this assay, from the lowest: compound 2; then compounds 3 and 4 (each within the scatter of the next); then compound 1.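

Swapping 4-acetylphenyl for the smaller 2-chloropyridin-4-yl on this saturated chain carbon leaves the number unchanged within the scatter (a 1.3-fold higher number from compound 3 to compound 4 (0.10 log units; within the scatter)), so the two groups cannot be told apart here. The 4-nitrophenyl group stays distinct from 2-chloropyridin-4-yl (a 7.5-fold higher number from compound 2 to compound 4 (0.88 log units; beyond the scatter)). With 2-chloropyridin-4-yl held constant, the far larger step comes from the other site, benzyloxy in place of methyl (a 73-fold lower number from compound 1 to compound 4 (1.87 log units; beyond the scatter)).

No evidence here explains these steps. On these data alone, whether a saturated amine such as morpholine or a carboxylic acid would be tolerated on the outer ring remains open.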